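The source may hold more compounds than are shown below. What is called first, only, known or untested is meant among the compounds shown, and "the series" means these compounds.

In a functional assay on HT-29 cells (Homo sapiens) for antiproliferative activity, read by sulforhodamine B assay, with a stated time of 48 h (a higher number here means a weaker inhibitor, a lower number a stronger inhibitor), compound 1 (`CCc1ccccc1OS(=O)(=O)c1ccc(N2CCN(C)C2=O)cc1`) gives 4600 nM, the lowest of the numbers at hand. Compound 3 (`CN1CCN(c2ccc(S(=O)(=O)Oc3ccc(Cl)cc3)cc2)C1=O`) gives 12000 nM. Placing 4-chlorophenyl in place of 2-ethylphenyl on an oxygen thus produces a 2.6-fold higher number from compound 1 to compound 3 (0.42 log units; beyond the scatter). Compound 2 (`CN1CCN(c2ccc(S(=O)(=O)Oc3cccc(F)c3)cc2)C1=O`) gives > 100000 nM, which is a limit of the assay and not a number. With 3-fluorophenyl in place of 2-ethylphenyl on an oxygen, the data show an at least 21-fold higher number from compound 1 to compound 2 (1.33 log units; beyond the scatter). Exchanging the two aryl groups gives an at least 8.3-fold lower number from compound 2 to compound 3 (0.92 log units; beyond the scatter).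

Compound 4 (`CCCN1CCN(c2ccc(S(=O)(=O)Oc3ccccc3CC)cc2)C1=O`) keeps the 2-ethylphenyl group and differs elsewhere: ethyl in place of hydrogen on a saturated chain carbon bound to an amide-type nitrogen in a ring. Methyl thus becomes propyl on the amide-type nitrogen in a ring. All three measured steps concern the group on an oxygen, so none of them tests this place. They bear on it only indirectly, showing that this assay can respond to a single change anywhere from a 2.6-fold higher number from compound 1 to compound 3 (0.42 log units; beyond the scatter) to an at least 21-fold higher number from compound 1 to compound 2 (1.33 log units; beyond the scatter). They offer no direction for the new change, so no step beyond the scatter is expected in this assay, though the uncertainty is wide. For compound 4, the estimated value is 5000 nM, with an expected range from 1500 nM to 17000 nM. The estimate amounts to an expected 1.1-fold higher number from compound 1 to compound 4 (0.04 log units; within the scatter).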

Compound 4, half-maximal inhibitory concentration: > 100000 nM
Compound 4 ended at the assay's limit; the forecaster's own chance of this, stated with the estimate: 7%; middle value at least 20-fold (1.30 log units) from the limit.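

In this assay, among these compounds, the change from methyl to propyl on the amide-type nitrogen in a ring gives an at least 21-fold higher number from compound 1 to compound 4 (1.33 log units; beyond the scatter), so this place, which none of the earlier steps tested, is far from indifferent, and keeping the 2-ethylphenyl group on the oxygen does not preserve the activity of compound 1. Compound 4 gives > 100000 nM, which is a limit of the assay and not a number. The step therefore fixes only the smallest possible size of this change, and how much weaker compound 4 truly is remains unknown: the limit of > 100000 nM in this assay, at which 2 of the 4 values shown sit.

The compounds shown hold only methyl and propyl at this place, so it remains open whether the response falls gradually or abruptly with chain length, and how an ethyl chain, the bare amide hydrogen or a chain ending in an amine or a carboxylic acid would read. On these data alone, it also remains open whether propyl has the same effect when the group on the oxygen is 4-chlorophenyl instead of 2-ethylphenyl.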